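This account rests on a few compounds, and the source may have more. Where it says the series, first, only, none or still open, it means among the compounds named here.

Working notes on the series in a physicochemical assay for solubility, read by spectrophotometry, in phosphate buffer, with a stated time of 2 h, at pH 7.4 (on this read-out lower numbers stand for lower solubility and higher numbers for higher solubility), following the step from compound 1 to compound 4.

Compound 1, `COc1ccc2[nH]c(C(=O)N3CC(=O)N(Cc4ccccc4)[C@@H](CN4CCCCC4)C3)cc2c1`, returns in this assay only a limit, > 25000 nM, and not a number (the limit of > 25000 nM in this assay, at which 1 of the 3 values shown sits). Compound 2, `COc1cccc(CN2C(=O)CN(C(=O)c3cc4cc(OC)ccc4[nH]3)C[C@@H]2CCc2ccccc2)c1`, gives 5100 nM in this assay. Compound 3, `COc1ccc2[nH]c(C(=O)N3CC(=O)N(Cc4cccc(OC(F)F)c4)[C@@H](CN4CCCCC4)C3)cc2c1`, gives 26400 nM in this assay. Going by the values given here, the single one-place step measured so far, a step that the limit leaves unreadable from compound 1 to compound 3, cannot be sized, since compound 1 sits at a limit. Compound 2 differs from the others in more than one place and offers no one-place comparison.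

Compound 4, `COc1ccc2[nH]c(C(=O)N3CC(=O)N(Cc4ccccc4)[C@@H](CN4CC5(CCC5)C4)C3)cc2c1`, is not yet measured. It differs from compound 1 in one place: a group of 7 heavy atoms (6 carbon, 1 nitrogen; one four-membered non-aromatic ring of carbon only, one four-membered non-aromatic ring with 1 hetero atom) in place of a group of 6 heavy atoms (5 carbon, 1 nitrogen; one six-membered non-aromatic ring with 1 hetero atom), on a saturated chain carbon bound to a saturated ring carbon. Among the compounds with values here, no measured step touches this position, and the only measured step, which alters a different part of the molecule, is unreadable, so no size can be borrowed from it. Compound 4 is therefore expected to give about 25000 nM in this assay, with a range from 10000 nM to 60000 nM. The step of a number no higher from compound 1 to compound 4 (the limit leaves the size open) is expected to be none beyond the scatter, and there is a fair chance that this assay again reports only a limit for compound 4.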

Compound 4, solubility: 60700 nM
For compound 4 the middle estimate is 2.4-fold (0.39 log units) below the measured one, and the stated range ends below it.
By their numbers in this assay, from the lowest: compound 2; then compound 3; then compound 4.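

The step from compound 1 to compound 4 cannot be read in this assay, and no new size can be stated, because compound 1 returns only a limit and not a number: the limit of > 25000 nM in this assay, at which 1 of the 4 values shown sits.

Compound 4 carries a different group in place of the piperidin-1-yl group of compound 1. The compounds shown leave open how large any difference between these two compounds in this assay is.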